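Microsomal stability across the shared core

The source may hold more compounds than are shown below. What is called first, only, known or untested is meant among the compounds shown, and "the series" means these compounds.

Compound 1 `COc1ccc(-c2c(C)nc3c(N4CC[C@@H](NC(=O)NC(C)C)C4)cc(C)nn23)cc1OC` and compound 2 `COc1ccc(-c2c(C)nc3c(N4CC[C@@H](NS(=O)(=O)c5ccc(NC(C)=O)cc5)C4)cc(C)nn23)cc1OC` share one core. In an ADME assay on microsomes from liver (Homo sapiens) for metabolic stability, read by LC-MS, with NADPH named in the record, with a stated time of 60 min, tested at 1 uM, in the absence of a further agent (a lower number here means that less of the compound is left, a higher number that more of the compound is left), compound 1 reaches > 95%, which is a limit of the assay and not a number. In this assay compound 2 likewise sits at > 95%, again a limit. Both results coincide with the limit of > 95% in this assay, at which 2 of the 2 values shown sit, so compound 2 stands exactly where compound 1 stands, with nothing beyond that limit known. Compound 3 `COc1ccc(-c2c(C)nc3c(N4CC[C@@H](NS(=O)(=O)c5ccc(C#N)cc5)C4)cc(C)nn23)cc1OC` differs from compound 2 by cyano in place of acetamido on an aromatic carbon. Within the data shown here, no measured step between compounds exists here. The step of a number at least 2 percentage points lower from compound 2 to compound 3 (that floor lies within the scatter) is expected to stay within the usual scatter. Compound 3 is therefore estimated at 93%, between 80% and 99%, most likely reported once more as a limit.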

Compound 3, percent of the compound remaining: > 95%
Compound 3 gave a limit, no number; the forecaster's own chance of this, stated with the estimate: 60%; at least 2 percentage points between middle value and limit.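

No new step can be read among compound 1, compound 2 and compound 3, because all three results are limits: the limit of > 95% in this assay, at which 3 of the 3 values shown sit. The compounds shown leave open whether cyano in place of acetamido alters the percent of compound remaining in this assay.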